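A few compounds are considered here, and "the series" means these few. Any claim that something is new, unique, unknown or untested is made for them only; others in the source may bear on it.

Compound 1 `CCOC(=O)C(=O)CC(=O)/C=C/c1cn(Cc2ccc(Cl)cc2)c2ccccc12`: 40 uM
Compound 2 `C=C(C)Cn1cc(/C=C/C(=O)CC(=O)C(=O)O)c2ccccc21`: 2.5 uM
Compound 3 `O=C(/C=C/c1cn(-c2ccc(Cl)cc2)c2ccccc12)CC(=O)C(=O)O`: 31 uM

In an assay on isolated protein for inhibition of DNA nucleotidylexotransferase (Homo sapiens), read by scintillation counting, with a stated time of 10 min (a lower number here means a stronger inhibitor, a higher number a weaker inhibitor), compound 3 gives 31 uM, the second highest of the three numbers. Compound 1 sits nearest with 40 uM, a gap that lies within the scatter, while compound 2 with 2.5 uM lies furthest away. Among the compounds with values here, the only single step measured so far is a 12-fold higher number from compound 2 to compound 3 (1.09 log units; beyond the scatter), in which 4-chlorophenyl replaced 2-methylprop-2-en-1-yl on the aromatic nitrogen. Compound 4 `O=C(/C=C/c1cn(Cc2ccc(Cl)cc2)c2ccccc12)CC(=O)C(=O)O` has not been measured yet; it differs from compound 3 by 4-chlorobenzyl in place of 4-chlorophenyl on an aromatic nitrogen. The group on the nitrogen therefore changes once more, and the measured step shows that this place can shift the number by a large amount. Within the data shown here, the 4-chlorobenzyl also sits on the nitrogen of compound 1, which carries an ethyl ester where compound 4 carries the free acid; for that pair no step has been measured. The expected step is a 3.1-fold lower number from compound 3 to compound 4 (0.49 log units; beyond the scatter), a lower number, though with considerable uncertainty. The estimate for compound 4 is 10 uM, within a range from 3 uM to 40 uM.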

Compound 4, concentration for 50% inhibition: 10 uM
Beside the measured number, compound 4's estimate shows no gap at the digits printed; the range from low to high includes it.
By their numbers in this assay, from the lowest: compound 2; then compound 4; then compounds 3 and 1 (each within the scatter of the next).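

Placing 4-chlorobenzyl in place of 4-chlorophenyl on the aromatic nitrogen gives a 3.1-fold lower number from compound 3 to compound 4 (0.49 log units; beyond the scatter) in this assay, so adding one saturated carbon to this group moves the number down. The 2-methylprop-2-en-1-yl group still keeps the lower number, as the change with 4-chlorophenyl in place of 1-methylethenyl on a saturated chain carbon bound to an aromatic nitrogen gives a 4.0-fold higher number from compound 2 to compound 4 (0.60 log units; beyond the scatter). The result also provides the first acid and ester pair, since hydrogen in place of ethyl on an oxygen next to a carbonyl group gives a 4.0-fold lower number from compound 1 to compound 4 (0.60 log units; beyond the scatter), with the free acid carrying the lower number.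

Still open, going by these compounds, is how a plain benzyl without chlorine, or a chain ending in an amine, would behave on this nitrogen. The data shown offer no explanation for any of these shifts.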